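The source may hold more compounds than are shown below. What is called first, only, known or untested is meant among the compounds shown, and "the series" means these compounds.

The measured compounds and their values in a physicochemical assay for lipophilicity; on this read-out lower numbers stand for lower lipophilicity and higher numbers for higher lipophilicity:

compound 1, `Cc1cc(C)n(-c2ccc(Cl)c(C(=O)NC(=O)Nc3nc4ccc(S(=O)(=O)CCCN5CCN(C)CC5)cc4s3)c2)n1`: 2.5
compound 2, `CN1CCN(CCCS(=O)(=O)c2ccc3nc(NC(=O)NC(=O)c4cc(-n5cccc5)ccc4Cl)sc3c2)CC1`: 2.6
compound 3, `Cc1ccn(-c2ccc(Cl)c(C(=O)NC(=O)Nc3nc4ccc(S(=O)(=O)CCCN5CCN(C)CC5)cc4s3)c2)n1`: 2.6

Compound 2 stands level with compound 3 at the digits given, the two together the highest of the three numbers, and its furthest neighbour is compound 1, with a number 0.10 log units higher from compound 1 to compound 2 (within the scatter). The other two steps are of the same kind: a number 0.10 log units higher from compound 1 to compound 3 (within the scatter) and no change at the digits printed from compound 2 to compound 3 (within the scatter). All three steps change only the group on the aromatic carbon of the shared core, and none of them moves this assay beyond the scatter.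

Compound 4, `CN1CCN(CCCS(=O)(=O)c2ccc3nc(NC(=O)NC(=O)c4cc5c(ccn5C)cc4Cl)sc3c2)CC1`, is the next compound in this series. It differs from compound 2 by 5-chloro-1-methyl-1H-indol-6-yl in place of 2-chloro-5-(1H-pyrrol-1-yl)phenyl on a carbonyl carbon. The change again lies in the same part of the shared core that the three measured steps alter, and it keeps the heavy-atom count, the ring count and the count of donors and acceptors almost unchanged. Since every measured step in this region sits within the scatter, no step beyond the scatter is expected for compound 4 in this assay. Compound 4 is therefore estimated at 2.7, within 2.3 to 3.1. That estimate means an expected step of a number 0.10 log units higher from compound 2 to compound 4 (within the scatter).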

Compound 4, distribution coefficient: 2.8
Beside the measured number, compound 4's estimate is 0.10 log units below it, and the stated range covers the measured number.
By their numbers in this assay, from the lowest: compounds 1, 2, 3 and 4 (each within the scatter of the next).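

In this assay, going by these compounds alone, putting 5-chloro-1-methyl-1H-indol-6-yl in place of 2-chloro-5-(1H-pyrrol-1-yl)phenyl on the carbonyl carbon gives a number 0.20 log units higher from compound 2 to compound 4 (within the scatter) and so extends the picture from the earlier steps, which exchanged only the group on an aromatic carbon, to a replacement of the whole group on the carbonyl carbon. Across this one change, the leaving and entering groups have the same ring types, the same hydrogen-bond donor and acceptor counts and no net charge, so the result shows only that a new arrangement of these same kinds of rings at this place stays within the scatter. No supporting observation is available to explain the result.

The compounds shown leave open how this read-out would respond if the group on the carbonyl carbon carried an amine or a carboxylic acid, since every group shown there is an uncharged chlorine-bearing aromatic group. On these data alone, it also remains open whether a longer chain in place of the methyl on the indole nitrogen would stay within the scatter.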